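Hydrazide to Primary Amide on a Shared Core

The source may hold more compounds than are shown below. What is called first, only, known or untested is meant among the compounds shown, and "the series" means these compounds.

Three compounds have been measured in a functional assay on HeLa cells (Homo sapiens) for cytotoxicity, read by MTT assay, with a stated time of 48 h; on this read-out higher numbers stand for weaker inhibition and lower numbers for stronger inhibition:

compound 1, `Cc1n[nH]c2c1C(c1ccc(N(C)C)cc1)C(C(=O)NN)=C(N)N2`: 51300 nM
compound 2, `Cc1n[nH]c2c1C(c1ccc(N(C)C)cc1)C(C(=O)n1ncc(C#N)c1N)=C(N)N2`: 60200 nM
compound 3, `Cc1n[nH]c2c1C(c1ccc(N(C)C)cc1)C=C(N)N2`: 27400 nM

Compound 1 stands second highest of the three numbers. Its nearest neighbour is compound 2, a 1.2-fold higher number from compound 1 to compound 2 (0.07 log units; within the scatter); its furthest is compound 3, a 1.9-fold lower number from compound 1 to compound 3 (0.27 log units; within the scatter). Both of these steps stay within the scatter, so the three measured compounds cannot be ranked against one another.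

Compound 4 is `Cc1n[nH]c2c1C(c1ccc(N(C)C)cc1)C(C(N)=O)=C(N)N2`. It differs from compound 1 in one place: hydrogen in place of amino on an amide-type nitrogen. Within the data shown here, two measured steps bear on this site. Replacing the whole aminocarbamoyl with hydrogen, a 1.9-fold lower number from compound 1 to compound 3 (0.27 log units; within the scatter), and replacing the aminoamino with a larger group, a 1.2-fold higher number from compound 1 to compound 2 (0.07 log units; within the scatter), both left the number within the scatter. The change to compound 4 is smaller than either, so no step beyond the scatter is expected in this assay, in either direction. Compound 4 is therefore expected to give 45000 nM, with a range from 20000 nM to 100000 nM, which means a step of a 1.1-fold lower number from compound 1 to compound 4 (0.06 log units; within the scatter) is estimated.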

Compound 4, half-maximal inhibitory concentration: 5770 nM
Compound 4: the middle estimate sits 7.8-fold (0.89 log units) above what was measured, and the stated range ends above it.
By their numbers in this assay, from the lowest: compound 4; then compounds 3, 1 and 2 (each within the scatter of the next, the first and the last beyond it).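

Removing one amino group, which turns the hydrazide into a primary amide, gives an 8.9-fold lower number from compound 1 to compound 4 (0.95 log units; beyond the scatter) in this assay, so this site can respond strongly to a very small edit, something the close numbers of compounds 1 and 2 did not reveal. The carbamoyl group itself also counts: placing it on the double-bonded ring carbon gives a 4.7-fold lower number from compound 3 to compound 4 (0.68 log units; beyond the scatter), and amino in place of 5-amino-4-cyano-1H-pyrazol-1-yl on the carbonyl carbon gives a 10-fold lower number from compound 2 to compound 4 (1.02 log units; beyond the scatter), so among these compounds only the plain carbamoyl brings the number down this far. Nothing available explains why this small change matters so much. From the compounds shown here alone, whether an N-methyl amide would keep the lower number remains open. So does the outcome with a carboxylic acid or a nitrile in place of the carbamoyl.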